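Carbamoyl for Hydroxy on the Cyclohexyl Ring

This account rests on a few compounds, and the source may have more. Where it says the series, first, only, none or still open, it means among the compounds named here.

Of the compounds shown here, three built on a shared core have been measured in an assay on isolated protein for inhibition of protein kinase C delta type (Homo sapiens), read by TR-FRET, with a stated time of 2 h; on this read-out lower numbers stand for stronger inhibition and higher numbers for weaker inhibition. Compound 1 `N#Cc1cnc(NCc2ccccc2C(F)(F)F)cc1N[C@H]1CC[C@@H](O)CC1` gives 4500 nM. Compound 2 `CO[C@H]1CC[C@@H](Nc2cc(NCc3cnccc3C(F)(F)F)ncc2C#N)CC1` gives 5000 nM, and compound 3 `N#Cc1cnc(NCc2cnccc2C(F)(F)F)cc1NC1CCOCC1` gives 9800 nM. Compound 1 and compound 2 sit within the scatter of each other, while compound 3 lies beyond the scatter from compound 1.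

The new compound 4 `N#Cc1cnc(NCc2ccccc2C(F)(F)F)cc1N[C@H]1CC[C@@H](C(N)=O)CC1` differs from compound 1 in one place: carbamoyl in place of hydroxy on a saturated ring carbon.

Within the data shown here, none of the measured pairs changes this group. Among the measured compounds shown here, the only single-point step among the measured compounds is a 2.0-fold higher number from compound 2 to compound 3 (0.29 log units; within the scatter), and it concerns the ring that carries the amine rather than the hydroxy position, so it does not speak to the carbamoyl for hydroxy exchange. For the measured compounds named here, it shows only that one swap of a saturated ring on this core left the number within the usual scatter. Going by the values given here, with no direct precedent, the exchange in compound 4 is expected to move the number little, in either direction, and not beyond the scatter. The step from compound 1 is estimated as a 1.1-fold lower number from compound 1 to compound 4 (0.05 log units; within the scatter). Compound 4 is therefore expected to give about 4000 nM, within a range from 1500 nM to 12000 nM.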

Compound 4, half-maximal inhibitory concentration: 640 nM
For compound 4 the middle estimate is 6.3-fold (0.80 log units) above the measured one, and the stated range ends above it.
By their numbers in this assay, from the lowest: compound 4; then compounds 1, 2 and 3 (each within the scatter of the next, the first and the last beyond it).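

In this assay, among these compounds, carbamoyl in place of hydroxy on a saturated ring carbon gives a 7.0-fold lower number from compound 1 to compound 4 (0.85 log units; beyond the scatter), so this position on the six-membered carbon ring responds to the group it carries, which the earlier compounds could not show because none of them changed this group. By the computed counts, hydroxy and carbamoyl each hold 1 hydrogen-bond donor and 1 hydrogen-bond acceptor, while the group grows from 1 heavy atom to 3 and gains a double bond, so the step comes with a change in size and make-up of the group and not with a change in those two counts. No measurement available here explains why the number falls.

The compounds shown leave open whether this step is particular to carbamoyl or would also appear with another group in the same place, such as a carboxylic acid, an amine, or a longer chain ending in carbamoyl. As far as these compounds go, it is also open whether the same exchange would give a step of this size on the core of compound 2, which differs from compound 1 in more than this one group.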